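Rearranging the Fluorines on a Difluorophenyl Group

The source may report more compounds than this note shows. Statements on the series, on what has been measured and on what is new or still open speak of the compounds shown alone.

Of the compounds shown here, two with the same core have been measured so far. In a functional assay on PANC-1 cells (Homo sapiens) for inhibition, read by MTT assay, with a stated time of 48 h (a lower number here means a stronger inhibitor, a higher number a weaker inhibitor), compound 1 `Cc1nnsc1CO/N=C/c1c(C)nn(C)c1Oc1ccc(Br)cc1` gives 12800 nM and compound 2 `Cc1nnsc1CO/N=C/c1c(C)nn(C)c1Oc1cccc(F)c1F` gives 12200 nM as its result, which places the two level with each other. Compound 3 `Cc1nnsc1CO/N=C/c1c(C)nn(C)c1Oc1cc(F)cc(F)c1` has not yet been measured. It keeps everything in compound 2 except one group, with 3,5-difluorophenyl in place of 2,3-difluorophenyl on an oxygen on an aromatic ring, and the counted difference is 3,5-difluorophenyl in place of 2,3-difluorophenyl on an oxygen on an aromatic ring in full. The same atoms are present in both, joined differently. Among the measured compounds shown here, only one measured step bears on this change, namely a 1.0-fold lower number from compound 1 to compound 2 (0.02 log units; within the scatter) for the exchange of 4-bromophenyl for 2,3-difluorophenyl at that same place. For the measured compounds named here, no measured step yet shows what moving the fluorines does, so this is thin evidence. Even so, a change of group there has so far left the number in this assay unmoved, and no shift beyond the scatter is expected. The estimate amounts to an expected 1.0-fold lower number from compound 2 to compound 3 (0.01 log units; within the scatter) in this assay. For compound 3 the expected value is 12000 nM with an estimated range from 6000 nM to 24000 nM around it.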

Compound 3, half-maximal inhibitory concentration: > 50000 nM
Compound 3 gave a limit, no number; the forecaster's own chance of this, stated with the estimate: 10%; at least 4.1-fold (0.61 log units) between middle value and limit.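

Compound 3 gives a limit of the assay, not a number, in this assay: the limit of > 50000 nM in this assay, at which 1 of the 3 values shown sits. Even so, the change can be read: exchanging 2,3-difluorophenyl for 3,5-difluorophenyl, which uses the same atoms joined differently, gives an at least 4.0-fold higher number from compound 2 to compound 3 (0.61 log units; beyond the scatter). This position looked indifferent when only compound 1 and compound 2 were known, but it clearly does respond to a change of group, and the mere presence of two fluorines on the ring does not settle the outcome. Measured against the bromine-bearing ring, the exchange of 4-bromophenyl for 3,5-difluorophenyl gives an at least 3.9-fold higher number from compound 1 to compound 3 (0.59 log units; beyond the scatter), so the loss appears against both earlier compounds.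

The compounds shown leave open how far compound 3 lies past its limit, and so the full size of both steps, as well as what it is about the arrangement of the fluorines that produces the change. They also leave open what an unsubstituted phenyl ring, or a ring carrying a methoxy group, an amine or a carboxylic acid, would give at this place in this assay.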